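Chloro in Place of Hydrogen Across Two Related Cores

The compounds below may be only part of what the source reports. "The series", "measured", "known", "first", "only" and "open" are said of these compounds alone.

Compound 1 `O=C(N/N=C/c1ccccc1)c1cccnc1Nc1cccc(C(F)(F)F)c1` is tested in a functional assay on the whole organism (strain Wistar) for inhibition, with Rattus norvegicus as the target, read by paw edema, with a stated time of 1 h, at a dose of 10 mg/kg by the intraperitoneal route (on this read-out lower numbers stand for less inhibition and higher numbers for more inhibition at the one dose given (going by the name of the read-out)), where compound 1 gives 53.9%. Compound 2 `O=C(N/N=C/c1ccc(Cl)cc1)c1cccnc1Nc1cccc(C(F)(F)F)c1` carries the change (chloro in place of hydrogen on an aromatic carbon), and in this assay compound 2 gives 67.2%, so that a number 13.3 percentage points higher from compound 1 to compound 2 (beyond the scatter). Compound 3 `CNc1ncccc1C(=O)N/N=C/c1ccccc1` has a different core; how its core differs from that of compound 1 is not broken down here. In this assay compound 3 gives 67.6%, a number higher than that of compound 1 and within the scatter of that of compound 2. Compound 4 `CNc1ncccc1C(=O)N/N=C/c1ccc(Cl)cc1` is not yet measured; it differs from compound 3 by chloro in place of hydrogen on an aromatic carbon, the same change, at the same place, as that from compound 1 to compound 2. Beside the measured step of a number 13.3 percentage points higher from compound 1 to compound 2 (beyond the scatter), the author expects a number 6.4 percentage points higher from compound 3 to compound 4 (within the scatter), resting on the one measured pair and on the number of compound 3 being 67.6% already. The estimate for compound 4 in this assay is therefore 74%, expected between 60% and 86%.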

Compound 4, a percentage reported as inhibition, in the whole organism at one dose (the size of the read-out at that dose, not a potency): 54.7%
Compound 4: the middle estimate sits 19.3 percentage points above what was measured; measured number outside the range, below it.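

In this assay the same chloro change, at the same place, now gives a number 12.9 percentage points lower from compound 3 to compound 4 (beyond the scatter). Set beside the earlier step, the two do not agree: the same change on two cores in this assay, a number 13.3 percentage points higher (beyond the scatter) from compound 1 to compound 2 and a number 12.9 percentage points lower (beyond the scatter) from compound 3 to compound 4, 26.2 percentage points apart, beyond the scatter of two such steps. This shows that in this series the step measured on the core of compound 1 cannot be carried over to the core of compound 3, in either size or direction, but it does not show what in the two cores sets the steps apart, and with a single pair on each core it gives no rule for any other core.

The compounds shown carry only hydrogen or chloro at this place, so it remains open how a fluoro, a methoxy or a carboxylic acid there would behave on each core. Also open, on these data alone, is whether the opposite steps would persist with an ethyl group or a longer chain on the amine nitrogen that carries the methyl in compound 3.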